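Methyl Additions on the Shared Core: Growth Inhibition Notes

The compounds below may be only part of what the source reports. "The series", "measured", "known", "first", "only" and "open" are said of these compounds alone.

Compound 3 `COc1cccc(-c2cc(O)c3c(C)ccnc3n2)c1` in a functional assay on PC-3 cells (Homo sapiens) (a higher number here means a weaker inhibitor of growth, a lower number a stronger inhibitor of growth), gives 26.3 nM. Compound 1 `COc1cccc(-c2cc(O)c3c(C)cc(C)nc3n2)c1` carries one more methyl, and in this assay compound 1 gives 309 nM; the change methyl in place of hydrogen on an aromatic carbon gave a 12-fold higher number from compound 3 to compound 1 (1.07 log units; beyond the scatter). Compound 2 `COc1ccccc1-c1cc(O)c2cccnc2n1` in this assay gives 29500 nM, the highest number of the three. Compound 4 `COc1ccccc1-c1cc(O)c2c(C)ccnc2n1` is the unmeasured analogue of compound 2 with the change (methyl in place of hydrogen on an aromatic carbon). This is the same kind of change as from compound 3 to compound 1, not the same: there the methyl entered next to the ring nitrogen, here it enters opposite the ring nitrogen and ortho to a fused ring. The difference between the core of compound 2 and the core of compound 3 is not broken down here. The expectation rests on compound 1, whose step a 12-fold higher number from compound 3 to compound 1 (1.07 log units; beyond the scatter) is the only measured one of this kind and lies at another place. Given that, only a small step is expected, a 3.0-fold lower number from compound 2 to compound 4 (0.47 log units; beyond the scatter). Compound 4 is estimated at 10000 nM in this assay, between 2000 nM and 45000 nM.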

Compound 4, concentration for 50% growth inhibition: 20900 nM
Beside the measured number, compound 4's estimate is 2.1-fold (0.32 log units) below it; the measured number falls inside the stated range.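

In this assay, methyl in place of hydrogen on the aromatic carbon opposite the ring nitrogen gives a 1.4-fold lower number from compound 2 to compound 4 (0.15 log units; within the scatter). On the core of compound 2 this change therefore shows no measurable shift, and the two measured cases show that it does not carry over as one fixed step: the same change on two cores in this assay, a 12-fold higher number (1.07 log units; beyond the scatter) from compound 3 to compound 1 and a 1.4-fold lower number (0.15 log units; within the scatter) from compound 2 to compound 4, 17-fold (1.22 log units) apart, beyond the scatter of two such steps. These two cases differ both in the core and in the place of the methyl, so they do not show which of the two accounts for the gap, and one step at each place gives no rule for the series.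

Going by these compounds, it remains open how a longer chain such as ethyl, or an amine, would behave at the carbon opposite the ring nitrogen. On these data alone, it also remains open whether a methyl at one place would give the same step on both cores.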